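Compound 2 and the tert-butyl change

The source may hold more compounds than are shown below. What is called first, only, known or untested is meant among the compounds shown, and "the series" means these compounds.

In a functional assay on a cell-free system (plasma, Homo sapiens), with a stated time of 3 min (on this read-out higher numbers stand for weaker inhibition and lower numbers for stronger inhibition), compound 1 `CC(C)(C)OC[C@@H](O)C(=O)N1[C@H](C(=O)NCc2cc(Cl)ccc2-n2cnnn2)C[C@@H]2C[C@@H]21` gives 500 nM. Compound 3 `CC(C)(C)C[C@@H](O)C(=O)N1CC[C@@H]2C[C@@]21C(=O)NCc1cc(Cl)ccc1-n1cnnn1` gives 620 nM, and compound 2 `O=C(NCc1cc(Cl)ccc1-n1cnnn1)[C@@H]1CC=NN1C(=O)[C@H](O)c1ccccc1F` gives 1100 nM. Compound 2 thus holds the highest of the three numbers, but its gap to compound 3 lies within the scatter, and only its gap to compound 1 lies beyond it.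

Compound 4 `CC(C)(C)[C@@H](O)C(=O)N1N=CC[C@H]1C(=O)NCc1cc(Cl)ccc1-n1cnnn1` has not yet been measured. It differs from compound 2 by tert-butyl in place of 2-fluorophenyl on a saturated chain carbon bound to a carbonyl carbon and an oxygen on a saturated carbon.

For the measured compounds named here, no measured pair isolates this change, so the expectation rests on indirect evidence. Compound 1 at 500 nM and compound 3 at 620 nM also carry tert-butyl, but on different cores and not on the same carbon, so they offer only loose support for a modestly lower number. The estimated 1.4-fold lower number from compound 2 to compound 4 (0.14 log units; within the scatter) points towards somewhat stronger inhibition, and no change beyond the scatter is expected in this assay. For compound 4 the estimated value is 800 nM, with an expected range of 250 nM to 2500 nM.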

Compound 4, half-maximal inhibitory concentration: 1400 nM
Compound 4: the middle estimate sits 1.8-fold (0.24 log units) below what was measured; the range from low to high includes it.
By their numbers in this assay, from the lowest: compounds 1, 3, 2 and 4 (each within the scatter of the next, the first and the last beyond it).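

On the saturated chain carbon bound to a carbonyl carbon and an oxygen on a saturated carbon, the series now has its first comparison that differs in one place: in this assay, tert-butyl in place of 2-fluorophenyl gives a 1.3-fold higher number from compound 2 to compound 4 (0.10 log units; within the scatter) and stays within the scatter. At this position and on this core, the read-out therefore does not separate a group with one six-membered aromatic ring of carbon only and 7 heavy atoms from a ring-free group with 4 heavy atoms. No measurement available here bears on why the two groups read alike.

From the compounds shown here alone, the two groups compared carry no net charge and have no hydrogen-bond donors or acceptors, so it remains open how the read-out at this carbon would respond to an amine, a carboxylic acid or a longer chain such as n-hexyl. Going by these compounds, it also remains open whether tert-butyl and 2-fluorophenyl would read alike on the core of compound 1 or the core of compound 3, as a single step at this position is available on one core only.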